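Three Limit-Bound Analogs and a Trifluorophenyl Newcomer

The source may hold more compounds than are shown below. What is called first, only, known or untested is meant among the compounds shown, and "the series" means these compounds.

Compound 1 `CC(C)[C@H](NC(=O)COc1cccc2ccccc12)C(=O)N[C@@H](CC(=O)O)C(=O)COc1cc(C(F)(F)F)cc(C(F)(F)F)c1`: only the limit > 100000 nM
Compound 2 `CC(C)[C@H](NC(=O)COc1cccc2ccccc12)C(=O)N[C@@H](CC(=O)O)C(=O)COc1ccc(C(N)=O)cc1`: only the limit > 100000 nM
Compound 3 `CC(C)[C@H](NC(=O)COc1cccc2ccccc12)C(=O)N[C@@H](CC(=O)O)C(=O)COc1cccc(F)c1`: only the limit > 100000 nM

In a functional assay on Jurkat cells (Homo sapiens) (a higher number here means a weaker inhibitor, a lower number a stronger inhibitor), compound 2 gives no number, only a limit. The same holds for the other two values (the limit of > 100000 nM in this assay, at which 3 of the 3 values shown sit). Within the data shown here, the one single-place comparison, a step that the two limits leave unreadable from compound 2 to compound 3, is therefore unreadable in size. Compound 4 `CC(C)[C@H](NC(=O)COc1cccc2ccccc12)C(=O)N[C@@H](CC(=O)O)C(=O)COc1ccc(F)c(F)c1F` differs from compound 2 by 2,3,4-trifluorophenyl in place of 4-carbamoylphenyl on an oxygen on a saturated carbon. Among the measured compounds shown here, no measured step bears readably on this change, so no step beyond the scatter can be foreseen in this assay, and compound 4 is expected to sit at the limit as well. Compound 4 is estimated at 150000 nM, within 50000 nM to 500000 nM. The step from compound 2 expected is a step that the limit leaves unreadable from compound 2 to compound 4.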

Compound 4, half-maximal inhibitory concentration: 35800 nM
Compound 4: the middle estimate sits 4.2-fold (0.62 log units) above what was measured; measured number below the stated range.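

In this assay, the group on this oxygen can clearly shift the result: 2,3,4-trifluorophenyl in place of 4-carbamoylphenyl gives an at least 2.7-fold lower number from compound 2 to compound 4 (0.44 log units; beyond the scatter). Fluorine as such is not enough, since replacing 3-fluorophenyl with 2,3,4-trifluorophenyl gives an at least 2.7-fold lower number from compound 3 to compound 4 (0.44 log units; beyond the scatter). Both steps are minimum sizes because the starting compounds give only a limit, not a number: the limit of > 100000 nM in this assay, at which 3 of the 4 values shown sit.

The compounds shown leave open how much each of the three fluorines contributes. From the compounds shown here alone, whether 2,3-difluorophenyl would keep this gain, or pentafluorophenyl extend it, also remains unknown.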